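Ring change on the amide nitrogen of compound 1

A few compounds are considered here, and "the series" means these few. Any claim that something is new, unique, unknown or untested is made for them only; others in the source may bear on it.

In a functional assay on MCF7 cells (Homo sapiens) for cytotoxicity, read by MTT assay, with a stated time of 72 h (a higher number here means a weaker inhibitor, a lower number a stronger inhibitor), compound 1 (`Cc1c(C)c2c(c(C)c1OC(=O)CCC(=O)NC1CC(C)(C)N([O])C(C)(C)C1)CC[C@@](C)(CCC[C@H](C)CCC[C@H](C)CCCC(C)C)O2`) gives > 300000 nM, which is a limit of the assay. Compound 2 (`Cc1c(C)c2c(c(C)c1OC(=O)CCC(=O)O)CCC(C)(C(=O)NCC1CC(C)(C)N([O])C1(C)C)O2`) gives > 300000 nM, also a limit. Compound 3 (`Cc1c(C)c2c(c(C)c1O)CCC(C)(C(=O)NCC1CC(C)(C)N([O])C1(C)C)O2`) gives > 300000 nM, again a limit. Among the compounds with values here, the only measured step is a step that the two limits leave unreadable from compound 2 to compound 3, and the series stands at the limit of > 300000 nM in this assay, at which 3 of the 3 values shown sit. Compound 4 (`Cc1c(C)c2c(c(C)c1OC(=O)CCC(=O)NC1CC(C)(C)N([O])C1(C)C)CC[C@@](C)(CCC[C@H](C)CCC[C@H](C)CCCC(C)C)O2`) differs from compound 1 by one change: a group of 10 heavy atoms (8 carbon, 1 nitrogen, 1 oxygen; one five-membered non-aromatic ring with 1 hetero atom) in place of a group of 11 heavy atoms (9 carbon, 1 nitrogen, 1 oxygen; one six-membered non-aromatic ring with 1 hetero atom), on an amide-type nitrogen. Compound 2 and compound 3 also carry a five-membered non-aromatic ring with 1 hetero atom. With compound 1 at the limit > 300000 nM, no step beyond the scatter is expected in this assay. The expected step is a number no higher from compound 1 to compound 4 (the limit leaves the size open). Compound 4 is estimated at 300000 nM, with an expected range of 100000 nM to 500000 nM.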

Compound 4, half-maximal inhibitory concentration: 95000 nM
Beside the measured number, compound 4's estimate is 3.2-fold (0.50 log units) above it, and the stated range ends above it.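

In this assay, within the data shown here, the ring on the amide-type nitrogen is the first place where a change can be read: the five-membered non-aromatic ring in place of the six-membered one gives an at least 3.1-fold lower number from compound 1 to compound 4 (0.49 log units; beyond the scatter). The size of this step remains only a bound, since the value for compound 1 is a limit. Compound 4 is the only compound shown with a value that is not a limit, and the rest of the series sits at: the limit of > 300000 nM in this assay, at which 3 of the 4 values shown sit.

The compounds shown leave open how far the number moves with an open-chain amine on this nitrogen in place of the ring. They also leave open whether a ring carrying a second nitrogen would keep the step.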